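Shortening the ether side chain of compound 1

The source may hold more compounds than are shown below. What is called first, only, known or untested is meant among the compounds shown, and "the series" means these compounds.

Compound 1: `CCCCOCCn1c(N2CCN(C)CC2)nc2ccccc21`, 38 nM
Compound 2: `CCCCN1CCN(c2nc3ccccc3n2CCOCC)CC1`, 15 nM
Compound 3: `CCCCOCCn1c(N2CCCN(C)CC2)nc2ccccc21`, 10 nM

In a functional assay on ileum for inhibition of histamine H1 receptor (Cavia porcellus) (on this read-out lower numbers stand for stronger inhibition and higher numbers for weaker inhibition), compound 1 gives the highest of the three numbers shown, with compound 2 the nearest and compound 3 the furthest. For the measured compounds named here, the only step measured within one change is a 3.8-fold lower number from compound 1 to compound 3 (0.58 log units; beyond the scatter), which concerns the saturated ring on the aromatic carbon, not the ether chain. Compound 4, `COCCn1c(N2CCN(C)CC2)nc2ccccc21`, has not yet been measured in this assay. It differs from compound 1 by hydrogen in place of propyl on a saturated chain carbon bound to an oxygen on a saturated carbon. Going by the values given here, no measured step touches the length of the ether chain; compound 2 carries a shorter ether chain but also a different group on the saturated ring, so its value shows only that such a chain is compatible with a low number. On these data the step from compound 1 to compound 4 is expected to be small, estimated as a 1.6-fold higher number from compound 1 to compound 4 (0.20 log units; within the scatter), with the direction open. Compound 4 is therefore expected to give about 60 nM, within a range of 20 nM to 200 nM.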

Compound 4, half-maximal inhibitory concentration: 13 nM
Compound 4: middle estimate off by 4.6-fold (0.66 log units), on the high side; measured number below the stated range.
By their numbers in this assay, from the lowest: compounds 3, 4 and 2 (each within the scatter of the next); then compound 1.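

In this assay, for the compounds shown here, a 2.9-fold lower number from compound 1 to compound 4 (0.47 log units; beyond the scatter) gives the first single-change reading on the ether chain, where butoxy is replaced by methoxy. With the 4-methylpiperazin-1-yl group held constant, the number therefore falls as the propyl portion is replaced by hydrogen, showing that this portion of the chain is not needed for a low number on this core. Nothing available accounts for this fall.

The compounds shown leave open whether the number changes gradually with chain length, since a single shortening cannot show how a propoxy chain would compare, or whether a longer hexyloxy chain would raise the number further. They also leave open whether a hydroxy group in place of methoxy would keep the low number, and whether the shortening has a similar result alongside 4-methyl-1,4-diazepan-1-yl.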